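Chloro for Methyl: Expected Dose of Compound 3

The source may hold more compounds than are shown below. What is called first, only, known or untested is meant among the compounds shown, and "the series" means these compounds.

Measured so far:
compound 1, `C/C(=N\NC(=O)Nc1cccc2ccccc12)c1ccc(C)cc1` — 300 mg/kg
compound 2, `COc1cc(/C=N/NC(=O)Nc2cccc3ccccc23)ccc1O` — 300 mg/kg

Both compounds were tested in a functional assay on the whole organism (strain Swiss albino) with Mus musculus as the target, with a stated time of 0.5 h; a higher number here means that more compound is needed for the effect, a lower number that less compound is needed. In this assay compound 1 gives 300 mg/kg, and compound 2 gives 300 mg/kg. At the digits shown compound 1 stands level with compound 2; the two values lie within the usual scatter, so nothing can be said about which needs less compound. For the measured compounds named here, no pair of measured compounds differs in only one place, so no single structural step with a measured size is available here.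

Compound 3, `C/C(=N\NC(=O)Nc1cccc2ccccc12)c1ccc(Cl)cc1`, has not yet been measured. It differs from compound 1 in one place: chloro in place of methyl on an aromatic carbon. The change keeps the size of the group the same in heavy atoms and adds no donors, acceptors or charge. With nothing in the measured pair to suggest that such a swap moves the dose, the expected step from compound 1 to compound 3 in this assay is no change at the digits printed from compound 1 to compound 3 (within the scatter), not beyond the scatter. Compound 3 is therefore estimated at 300 mg/kg, within a range of 100 mg/kg to 600 mg/kg.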

Compound 3, minimum effective dose: 300 mg/kg
Compound 3: the middle estimate sits on the measured number at the digits printed; the measured number falls inside the stated range.
By their numbers in this assay, from the lowest: compounds 1, 2 and 3 (each within the scatter of the next).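

Compound 1 and compound 2 differ in more than one place, so they could not show what a single change at one position does; the new pair can. Going from 4-methylphenyl to 4-chlorophenyl, with the rest of the core of compound 1 left untouched, gives no change at the digits printed from compound 1 to compound 3 (within the scatter) in this assay, so at this aromatic carbon, para to a large group, chloro and methyl cannot be told apart by the dose needed. No independent measurement bears on why the swap leaves the dose where it is, so this pair records an outcome and offers no explanation.

As far as these compounds go, one exchange between two small groups at one position says little about how far this position can be altered, and whether a larger or quite different group, such as an amine, a carboxylic acid or a longer chain, would shift the dose beyond the scatter remains open. From the compounds shown here alone, it also remains open whether chloro in place of methyl would give the same result on a different core, or at another position on this ring.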